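The source may hold more compounds than are shown below. What is called first, only, known or untested is meant among the compounds shown, and "the series" means these compounds.

In a functional assay on HT-29 cells (Homo sapiens) for inhibition, read by MTT assay, with a stated time of 48 h (on this read-out higher numbers stand for weaker inhibition and lower numbers for stronger inhibition), compound 1 `COc1ccc(-c2cc(-c3cc(OC)c(OC)c(OC)c3)nc(-c3ccccc3)n2)c(OC)c1` gives > 25000 nM, which is a limit and not a number. Compound 3 `COc1cc(-c2cc(-c3cccs3)nc(-c3ccccc3)n2)cc(OC)c1OC` gives > 25000 nM, which is also a limit. Compound 1 therefore stands at the limit of > 25000 nM in this assay, at which 2 of the 3 values shown sit. For the measured compounds named here, the only true number comes from compound 2 `COc1cc(-c2cc(-c3ccc(O)cc3)nc(-c3ccccc3)n2)cc(OC)c1OC`, at 11300 nM.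

Compound 4 `COc1cc(-c2cc(-c3ccc(N)cc3)nc(-c3ccccc3)n2)cc(OC)c1OC` differs from compound 1 in one place, where 4-aminophenyl takes the place of 2,4-dimethoxyphenyl on an aromatic carbon: 4-aminophenyl in place of 2,4-dimethoxyphenyl on an aromatic carbon.

Going by the values given here, two measured steps bear on this change. Putting 4-hydroxyphenyl in place of 2,4-dimethoxyphenyl gives an at least 2.2-fold lower number from compound 1 to compound 2 (0.34 log units; beyond the scatter). Putting thiophen-2-yl in place of 4-hydroxyphenyl gives an at least 2.2-fold higher number from compound 2 to compound 3 (0.34 log units; beyond the scatter). Both steps are at least modest and beyond the scatter, and they point the same way: of the three groups tried at this place, only the 4-hydroxyphenyl of compound 2 brings a value within measurable range. The entering 4-aminophenyl is, like that group, a phenyl with a single substituent named at the 4 position, so compound 2 at 11300 nM is the nearest guide. A step towards lower numbers, of about the same modest size, is therefore expected, estimated as an at least 2.5-fold lower number from compound 1 to compound 4 (0.39 log units; beyond the scatter). For compound 4 the expected value is 10000 nM, with an estimated range from 3500 nM to 25000 nM.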

Compound 4, half-maximal inhibitory concentration: > 25000 nM
Compound 4: no number, only a limit; the forecaster's own chance of this, stated with the estimate: 25%; middle value at least 2.5-fold (0.39 log units) away from the limit.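

Amino in place of hydroxy gives an at least 2.2-fold higher number from compound 2 to compound 4 (0.34 log units; beyond the scatter). A phenyl with a single group named at the 4 position is therefore not enough to bring a measurable value at this place on the shared core: of the four groups shown, only the 4-hydroxyphenyl of compound 2 does so, and the 4-aminophenyl of compound 4 goes against any wider pattern. The steps linking compound 4 to compound 1 and to compound 3 cannot be read, and compound 4 adds one more limit in this assay: the limit of > 25000 nM in this assay, at which 3 of the 4 values shown sit.

The compounds shown leave open whether the hydroxy group itself is what separates compound 2, at 11300 nM, from the others, or whether a 4-methoxyphenyl, a 4-fluorophenyl or a 4-carboxyphenyl at this place would also give a number. They also leave open how far compound 1, compound 3 and compound 4 lie past their limits, and whether a hydroxy group elsewhere on the phenyl ring would give a number at all.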